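This account rests on a few compounds, and the source may have more. Where it says the series, first, only, none or still open, it means among the compounds named here.

Working notes on the series. In a functional assay on MDA-MB-231 cells (Homo sapiens) for cytotoxicity, read by MTT assay, with a stated time of 48 h (a higher number here means a weaker inhibitor, a lower number a stronger inhibitor), compound 1 `O=C(/C=C/c1ccc2c(c1)B(O)OC2)c1ccc(I)cc1` gives 14900 nM, the highest of the three numbers. Compound 3 `O=C(/C=C/c1ccc2c(c1)B(O)OC2)c1ccc(C(F)(F)F)cc1` gives 9200 nM, and the step of a 1.6-fold lower number from compound 1 to compound 3 (0.21 log units; within the scatter) stays within the scatter. Compound 2 `O=C(/C=C/c1ccc2c(c1)B(O)OC2)c1ccc(OCc2ccccc2)cc1` gives 5300 nM, the step of a 2.8-fold lower number from compound 1 to compound 2 (0.45 log units; beyond the scatter) being the only one beyond it.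

Compound 4 `Nc1cccc(C(=O)/C=C/c2ccc3c(c2)B(O)OC3)c1` differs from compound 1 by 3-aminophenyl in place of 4-iodophenyl on a carbonyl carbon. Within the data shown here, no measured step exchanges the whole aryl group; the three known steps each replace one group on an aromatic carbon, and they span from within the scatter to a modest lowering. A step of similar or smaller size is therefore expected, direction uncertain. For compound 4 the estimate is 10000 nM, in the range 4000 nM to 25000 nM, which means an expected step of a 1.5-fold lower number from compound 1 to compound 4 (0.17 log units; within the scatter).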

Compound 4, half-maximal inhibitory concentration: 3200 nM
Compound 4: middle estimate off by 3.1-fold (0.49 log units), on the high side; the measured number lies below the stated range.
By their numbers in this assay, from the lowest: compounds 4, 2, 3 and 1 (each within the scatter of the next, the first and the last beyond it).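

Replacing 4-iodophenyl with 3-aminophenyl on the carbonyl carbon gives a 4.7-fold lower number from compound 1 to compound 4 (0.67 log units; beyond the scatter) in this assay, showing that this exchange of the whole aryl group lowers the number beyond the scatter. The entering group carries a hydrogen-bond donor and acceptor, whereas the leaving group carries neither, but the amine and its ring location change together, so the step cannot be assigned to either alone. No available data explain the lowering.

Still open, on these data alone, is whether 4-aminophenyl would match 3-aminophenyl. Also open, as far as these compounds go, is whether a hydroxyl or an acetamide could replace the amine.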